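The source may report more compounds than this note shows. Statements on the series, on what has been measured and on what is new or still open speak of the compounds shown alone.

Measured so far:
compound 1 `COc1ccc(-n2nnnc2Nc2cccc(Br)c2)cc1` — 138000 nM
compound 2 `COc1ccc(-n2nnnc2Nc2cccc(F)c2)cc1` — 127000 nM
compound 3 `COc1ccc(Nc2nnnn2-c2ccc(F)cc2)cc1` — 101000 nM

All three were measured in an ADME assay on HaCaT cells (Homo sapiens) for cytotoxicity, read by MTT assay, with a stated time of 72 h; on this read-out lower numbers stand for stronger inhibition and higher numbers for weaker inhibition. Compound 1 and compound 2 differ in one place only: bromo in place of fluoro on an aromatic carbon. That change gave a 1.1-fold higher number from compound 2 to compound 1 (0.04 log units; within the scatter). Compound 3 has the same atoms as compound 2 joined differently, and the difference between the two cores is not broken down here. Its value and those of compound 1 and compound 2 all lie within the scatter of one another.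

Compound 4 `COc1ccc(Nc2nnnn2-c2ccc(Br)cc2)cc1` has not yet been measured in this assay. It differs from compound 3 by bromo in place of fluoro on an aromatic carbon. The surroundings are not identical: in compound 1 the bromo sits meta to a large group, whereas in compound 4 it sits para to a large group, so this is the same kind of change rather than the same change.

For compound 4 the expected step is a 1.1-fold higher number from compound 3 to compound 4 (0.04 log units; within the scatter), set beside the measured 1.1-fold higher number from compound 2 to compound 1 (0.04 log units; within the scatter). This expectation rests on that single earlier step, which stayed within the scatter. Compound 4 is therefore estimated to give about 110000 nM, most likely between 60000 nM and 200000 nM.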

Compound 4, half-maximal inhibitory concentration: 103000 nM
Estimate against measurement, compound 4: 1.1-fold (0.03 log units) above; the range from low to high includes it.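

In this assay, putting bromo in place of fluoro on the 4-fluorophenyl group gave a 1.0-fold higher number from compound 3 to compound 4 (0.01 log units; within the scatter). Set beside the same swap on the other core, the two steps agree: the same change on two cores in this assay, a 1.1-fold higher number (0.04 log units; within the scatter) from compound 2 to compound 1 and a 1.0-fold higher number (0.01 log units; within the scatter) from compound 3 to compound 4, 1.1-fold (0.03 log units) apart, within the scatter of two such steps. This shows that the swap left the number within the usual scatter on both of these cores, so the small size of the step carried over from one core to the other; it does not show that the swap would do the same on a further core or in a different assay, and with steps this small it reveals no real effect of the swap that could be said to transfer.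

The compounds shown carry only fluoro or bromo as the varied group, so it remains open whether an amine, a carboxylic acid or a longer chain in that place would move the number beyond the scatter. From the compounds shown here alone, it also remains open what replacing the methoxy group shared by all four compounds would do.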